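The compounds below may be only part of what the source reports. "The series", "measured", "known", "first", "only" and "open" are said of these compounds alone.

Compounds measured so far:
compound 1, `Cc1cccc(-n2cc(-c3ccc(NS(=O)(=O)c4c[nH]c(=O)[nH]c4=O)cc3)nn2)c1`, 7490 nM
compound 2, `Cc1ccc(-n2cc(-c3ccc(NS(=O)(=O)c4c[nH]c(=O)[nH]c4=O)cc3)nn2)cc1`, 5630 nM
compound 3, `O=c1[nH]cc(S(=O)(=O)Nc2ccc(-c3cn(-c4cccc(F)c4)nn3)cc2)c(=O)[nH]1`, > 20000 nM

All three share a core and differ only in the aryl group on the triazole nitrogen. In a functional assay on OVCAR-3 cells (Homo sapiens) for antiproliferative activity, read by MTT assay, with a stated time of 24 h (a higher number here means a weaker inhibitor, a lower number a stronger inhibitor), compound 1 gives 7490 nM. Compound 2 gives 5630 nM, and a 1.3-fold lower number from compound 1 to compound 2 (0.12 log units; within the scatter). For compound 3 the assay returns only a limit, > 20000 nM, so its true value is not known; it sits at the limit of > 20000 nM in this assay, at which 1 of the 3 values shown sits. Compound 3 therefore stands at the weak end of what has been measured: an at least 2.6-fold higher number from compound 1 to compound 3 (0.42 log units; beyond the scatter), and an at least 3.5-fold higher number from compound 2 to compound 3 (0.55 log units; beyond the scatter).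

Compound 4, `O=c1[nH]cc(S(=O)(=O)Nc2ccc(-c3cn(-c4cccc(Cl)c4)nn3)cc2)c(=O)[nH]1`, has not yet been measured. The change from compound 3 is chloro in place of fluoro on an aromatic carbon, that is, 3-fluorophenyl to 3-chlorophenyl. For the measured compounds named here, no measured step swaps one halogen for another; the nearest step is the one from compound 1 to compound 3, in which fluoro replaced methyl on the same aromatic carbon, and that step was beyond the scatter. Since compound 3 is known only as a limit, the size of any step from it is uncertain. Compound 4 is estimated at 12000 nM, within 4000 nM to 40000 nM, which means an expected step of an at least 1.6-fold lower number from compound 3 to compound 4 (0.22 log units; that floor lies within the scatter).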

Compound 4, half-maximal inhibitory concentration: 2750 nM
For compound 4 the middle estimate is 4.4-fold (0.64 log units) above the measured one; the measured number lies below the stated range.
By their numbers in this assay, from the lowest: compound 4; then compounds 2 and 1 (each within the scatter of the next). At a limit, above all of these: compound 3.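

Compound 3 is held only at a limit, so the halogen swap has a floor rather than a full size: the limit of > 20000 nM in this assay, at which 1 of the 4 values shown sits. Even so, in this assay the choice of halogen on this aromatic carbon matters more than the earlier compounds could show, since exchanging fluoro for chloro, one heavy atom for one, gives an at least 7.2-fold lower number from compound 3 to compound 4 (0.86 log units; beyond the scatter). Chloro also parts from methyl at the same place, with a 2.7-fold lower number from compound 1 to compound 4 (0.44 log units; beyond the scatter), in the opposite direction from the fluoro for methyl change, so halogens at this position do not act as one class, and the 3-chlorophenyl group also stands apart from the 4-methylphenyl group, with a 2.0-fold lower number from compound 2 to compound 4 (0.31 log units; beyond the scatter).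

The compounds shown leave open whether bromo or trifluoromethyl at this place would follow chloro or fluoro, and what a methoxy group would do there. Nor do they say why chloro and fluoro part so far, which these numbers alone cannot tell.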